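Replacing 4-nitrophenyl with pyridin-4-yl in a cytotoxic series

This account rests on a few compounds, and the source may have more. Where it says the series, first, only, none or still open, it means among the compounds named here.

Of the compounds shown here, three sharing one core have so far been tested in a functional assay on HCT-116 cells (Homo sapiens) for cytotoxicity, read by sulforhodamine B assay, with a stated time of 48 h; a lower number here means a stronger inhibitor, a higher number a weaker inhibitor. There compound 1 `CC(=O)n1nc(NC(=O)c2ccccc2)c2c1CN(C(=O)c1ccccc1)C2` gives 580 nM as its value, and compound 3 `CC(=O)n1nc(NC(=O)c2ccccc2)c2c1CN(C(=O)c1ccc([N+](=O)[O-])cc1)C2` gives 16200 nM as its value, the higher of the two actual numbers. Compound 2 `CC(=O)n1nc(NC(=O)c2ccccc2)c2c1CN(C(=O)c1ccc(-c3ccccc3)cc1)C2` gives > 90000 nM as its result, which is a limit of the assay and not a number.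

Compound 4 `CC(=O)n1nc(NC(=O)c2ccccc2)c2c1CN(C(=O)c1ccncc1)C2` has not yet been measured. Its difference from compound 3 is pyridin-4-yl in place of 4-nitrophenyl on a carbonyl carbon, in words pyridin-4-yl in place of 4-nitrophenyl on a carbonyl carbon.

Going by the values given here, two measured steps bear most directly on this change. An added nitro group gave a 28-fold higher number from compound 1 to compound 3 (1.45 log units; beyond the scatter), a large step beyond the scatter. Phenyl in place of hydrogen gave an at least 150-fold higher number from compound 1 to compound 2 (2.19 log units; beyond the scatter), which is also large. Compound 4, like compound 1, carries no such substituent, so much of a 28-fold higher number from compound 1 to compound 3 (1.45 log units; beyond the scatter) is expected to be undone. Among the compounds with values here, no measured compound has a hetero atom in this ring, so a full return to the value of compound 1 is not assumed. The expected change is an 8.1-fold lower number from compound 3 to compound 4 (0.91 log units; beyond the scatter), a lower number beyond the scatter. For compound 4 the estimated value is 2000 nM, with an expected range from 350 nM to 12000 nM in this assay.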

Compound 4, half-maximal inhibitory concentration: 10000 nM
For compound 4 the middle estimate is 5.0-fold (0.70 log units) below the measured one; the range from low to high includes it.
By their numbers in this assay, from the lowest: compound 1; then compounds 4 and 3 (each within the scatter of the next). At a limit, above all of these: compound 2.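

In this assay the exchange of 4-nitrophenyl for pyridin-4-yl on this carbonyl carbon leaves the result unresolved (a 1.6-fold lower number from compound 3 to compound 4 (0.21 log units; within the scatter)), so the two compounds cannot be told apart here. The comparison with the phenyl of the parent shows something new: pyridin-4-yl in place of phenyl gives a large step (a 17-fold higher number from compound 1 to compound 4 (1.24 log units; beyond the scatter)), although this change adds no substituent to the ring and only brings in one hetero atom. The earlier compounds showed only that adding nitro or phenyl to this ring gave a higher number, whereas all three departures from the phenyl of compound 1 now lead to a higher number, and no compound shown goes against this.

Nothing measured here gives a reason for the step from phenyl to pyridin-4-yl. From the compounds shown here alone, it remains open how pyridin-3-yl or pyridin-2-yl would behave on this carbonyl carbon, and whether a small group such as fluoro, methoxy or methyl on the phenyl ring would keep the value of compound 1 or also move it to a higher number.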